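Trimethoxyphenyl in Place of Hydroxyphenyl: An Estimate

A few compounds are considered here, and "the series" means these few. Any claim that something is new, unique, unknown or untested is made for them only; others in the source may bear on it.

Compound 1 `Cc1cc(O)c(C2=NN(c3ccc(S(N)(=O)=O)cc3)C(c3ccccc3O)C2)cc1Cl` gives 2210 nM in a functional assay on NCI-H226 cells (Homo sapiens) for antiproliferative activity, with a stated time of 48 h (a lower number here means a stronger inhibitor of growth, a higher number a weaker inhibitor of growth), the lowest of the two numbers measured. Compound 2 `Cc1cc(O)c(C2=NN(c3ccc(S(N)(=O)=O)cc3)C(/C=C/c3ccccc3)C2)cc1Cl` gives 5210 nM in this assay, and the step of a 2.4-fold higher number from compound 1 to compound 2 (0.37 log units; beyond the scatter) shows that exchanging the group on the saturated ring carbon weakens growth inhibition modestly. Compound 3 `COc1ccc(C2CC(c3cc(Cl)c(C)cc3O)=NN2c2ccc(S(N)(=O)=O)cc2)c(OC)c1OC` differs from compound 1 by 2,3,4-trimethoxyphenyl in place of 2-hydroxyphenyl on a saturated ring carbon. Going by the values given here, only that one step bears on this change, so a weakening of similar size, beyond the scatter, is expected: a 1.7-fold higher number from compound 1 to compound 3 (0.24 log units; within the scatter). Compound 3 is estimated at 3800 nM in this assay, with a range from 1300 nM to 11000 nM.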

Compound 3, concentration for 50% growth inhibition: 3730 nM
Beside the measured number, compound 3's estimate is 1.0-fold (0.01 log units) above it; measured number inside the range.
By their numbers in this assay, from the lowest: compounds 1, 3 and 2 (each within the scatter of the next, the first and the last beyond it).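

In this assay, the step of a 1.7-fold higher number from compound 1 to compound 3 (0.23 log units; within the scatter) shows that 2,3,4-trimethoxyphenyl, with 0 hydrogen-bond donors, cannot be told apart from 2-hydroxyphenyl, with 1, on this saturated ring carbon. The step of a 1.4-fold lower number from compound 2 to compound 3 (0.15 log units; within the scatter) also lies within the scatter, so compound 3 cannot be separated from either compound 1 or compound 2, although those two differ beyond it. Nothing available here accounts for these results.

From the compounds shown here alone, whether a single methoxy group on the aromatic ring would read the same remains open. So does the outcome with an amine or a carboxylic acid at this position.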